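Chain Lengthening in Selenium Analogues: A Cytotoxicity Estimate

A few compounds are considered here, and "the series" means these few. Any claim that something is new, unique, unknown or untested is made for them only; others in the source may bear on it.

Compound 1 `CCCC(=O)OCSc1ccccc1C(=O)NCCCCCC(N)=O` and compound 2 `CCCC(=O)OCSc1ccccc1C(=O)NCCCCCCC(N)=O` share one core and differ by carbamoylmethyl in place of carbamoyl on a saturated chain carbon, five bonds along the chain from an amide-type nitrogen. In an ADME assay on CEM-SS cells (Homo sapiens) for cytotoxicity, read by XTT assay, with a stated time of 6 days (on this read-out higher numbers stand for lower toxicity in this test and lower numbers for higher toxicity in this test), compound 1 gives 16.3 uM, and compound 2 gives 10.4 uM, so the change made a 1.6-fold lower number from compound 1 to compound 2 (0.20 log units; within the scatter). Compound 3 `CCCC(=O)OC[Se]c1ccccc1C(=O)NCC(N)=O` rests on another core; the difference between the two cores is not broken down here. In this assay compound 3 gives 6.8 uM, lower than the value of compound 1 and within the scatter of compound 2. Compound 4 `CCCC(=O)OC[Se]c1ccccc1C(=O)NCCC(N)=O` differs from compound 3 by carbamoylmethyl in place of carbamoyl on a saturated chain carbon bound to an amide-type nitrogen. This is the same kind of change as from compound 1 to compound 2, though there the place was on a saturated chain carbon five bonds along the chain from an amide-type nitrogen, whereas here it is bound to an amide-type nitrogen. The expectation rests on the earlier result, which gave a 1.6-fold lower number from compound 1 to compound 2 (0.20 log units; within the scatter). A step of similar small size is expected, a 1.2-fold lower number from compound 3 to compound 4 (0.09 log units; within the scatter). Compound 4 is therefore estimated at 5.5 uM in this assay, probably between 2.5 uM and 12 uM.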

Compound 4, half-maximal toxic concentration: 10.5 uM
Beside the measured number, compound 4's estimate is 1.9-fold (0.28 log units) below it; low and high end bracket the measured number.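

In this assay, carbamoylmethyl in place of carbamoyl gave a 1.5-fold higher number from compound 3 to compound 4 (0.19 log units; within the scatter), a step too small to read as a real change. Set beside the earlier case, the two steps do not differ: the same change on two cores in this assay, a 1.6-fold lower number (0.20 log units; within the scatter) from compound 1 to compound 2 and a 1.5-fold higher number (0.19 log units; within the scatter) from compound 3 to compound 4, 2.4-fold (0.38 log units) apart, within the scatter of two such steps. So in these two pairs the change carries from one core to the other without a clear effect on the read-out, but this does not show a reversal of direction, nor that it would hold on further cores or at other places on the chain.

The compounds shown leave open how the core of compound 3 would respond to a chain longer than 2-carbamoylethyl. They also leave open what an amine or a carboxylic acid in place of the carbamoyl group would do.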